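Chain shortening on the shared core, cytotoxicity notes

The source may hold more compounds than are shown below. What is called first, only, known or untested is meant among the compounds shown, and "the series" means these compounds.

Measured so far in an ADME assay on HEL cells (Homo sapiens) for cytotoxicity, read by microscopy, with a stated time of 6 days; a higher number here means that more compound is tolerated, a lower number that less compound is tolerated:
compound 1, `CCCCCCCNc1cnc(C(=O)NCc2ccccc2)cn1`, gives > 100000 nM, a limit of the assay.
compound 2, `CCCCCCCCNc1cnc(C(=O)NCc2ccccc2)cn1`, gives 100000 nM.
compound 3, `CCCCCCCCNc1cncc(C(=O)NCc2ccccc2)n1`, gives > 100000 nM, again a limit of the assay.

Compound 3 thus stands at the limit only; compound 1 sits at the same limit, and compound 2 gives a number at the edge of it, so all three lie together: the limit of > 100000 nM in this assay, at which 2 of the 3 values shown sit.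

The next compound is compound 4, `CCCCCNc1cncc(C(=O)NCc2ccccc2)n1`. Compared with compound 3: hydrogen in place of propyl on a saturated chain carbon, five bonds along the chain from a nitrogen on an aromatic ring.

Among the compounds with values here, the only measured step, a number no higher from compound 1 to compound 2 (the limit leaves the size open), changes chain length on the same kind of carbon, and its size is left open by the limit. With every value at or beside the limit, no step beyond the scatter is expected for compound 4 in this assay: a number no higher from compound 3 to compound 4 (the limit leaves the size open). The estimate for compound 4 is 100000 nM, between 50000 nM and 200000 nM, most likely reported as a limit again.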

Compound 4, minimum cytotoxic concentration: > 100000 nM
Compound 4 was reported as a limit; the forecaster's own chance of this, stated with the estimate: 70%; the middle value sits exactly at the limit.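

Compound 3 and compound 4 both stand as limits in this assay, so no new step can be read from this pair: the limit of > 100000 nM in this assay, at which 3 of the 4 values shown sit.

The compounds shown leave open how much compound these chain lengths tolerate past that limit.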